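This account rests on a few compounds, and the source may have more. Where it says the series, first, only, none or still open, it means among the compounds named here.

Compound 2 `COc1cc(/C=C/C(=O)/C=C/c2cc(OC)c(OC)c(OC)c2)ccc1OCc1cn(CCCOc2cc(=O)oc3ccccc23)nn1` gives 76% in a functional assay on HCT-116 cells (Homo sapiens) for inhibition, read by sulforhodamine B assay, with a stated time of 48 h, tested at 50 uM; a lower number here means less inhibition of growth, a higher number more inhibition of growth at the concentration tested. Among the three measured compounds this is the second highest of the numbers: compound 3 `COc1cc(/C=C/C(=O)/C=C/c2cccc3ccccc23)ccc1OCc1cn(CCOc2cc(=O)oc3ccccc23)nn1` gives 83%, a result lying within the scatter of that of compound 2, whereas compound 1 `COc1ccc(/C=C/C(=O)/C=C/c2ccc(OCc3cn(CCCCCOc4cc(=O)oc5ccccc45)nn3)c(OC)c2)cc1` gives 35%, a gap well beyond the scatter. Compound 4 `COc1ccc(/C=C/C(=O)/C=C/c2ccc(OCc3cn(CCCOc4cc(=O)oc5ccccc45)nn3)c(OC)c2)cc1` has not yet been measured in this assay. It differs from compound 2 in one place: 4-methoxyphenyl in place of 3,4,5-trimethoxyphenyl on a double-bonded chain carbon bound to a double-bonded chain carbon. Because compound 1 with the same 4-methoxyphenyl group gives 35%, the change is expected to lower growth inhibition beyond the scatter, estimated as a number 31 percentage points lower from compound 2 to compound 4 (beyond the scatter). For compound 4 the expected value in this assay is 45%, with a range from 25% to 65%.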

Compound 4, percent growth inhibition at one concentration: 54%
Compound 4: middle estimate off by 9 percentage points, on the low side; the range from low to high includes it.
By their numbers in this assay, from the lowest: compound 1; then compound 4; then compounds 2 and 3 (each within the scatter of the next).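

Replacing 3,4,5-trimethoxyphenyl with 4-methoxyphenyl on a double-bonded chain carbon bound to a double-bonded chain carbon gives, in this assay, a number 22 percentage points lower from compound 2 to compound 4 (beyond the scatter). Going by these compounds alone, this is the first change seen at this position with the rest of the structure held fixed, and it shows that this group alone shifts growth inhibition, which the earlier compounds, differing in more than one place, could not show. No measurement shown gives a reason for this step. The compounds shown leave open how a 3,4-dimethoxyphenyl or a 4-aminophenyl group would fare at this position. They also leave open whether the step would hold with a longer chain elsewhere in the shared core.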